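This account rests on a few compounds, and the source may have more. Where it says the series, first, only, none or still open, it means among the compounds named here.

Measured compounds in a functional assay on HL-60 cells (Homo sapiens) for cytotoxicity, read by MTT assay, with a stated time of 48 h; on this read-out lower numbers stand for stronger inhibition and higher numbers for weaker inhibition:
- compound 1, `C=CC(=C)CC[C@@H]1[C@@]2(C)CCC[C@](C)(COC(=O)/C=C\c3ccc(O)cc3)[C@@H]2CC[C@@]1(C)O`: 14100 nM
- compound 2, `C=C1CC[C@@H]2[C@](C)(CCC[C@]2(C)C(=O)O)[C@H]1C/C=C(\C)C=O`: > 40000 nM
- compound 3, `C=C/C(C)=C/C[C@H]1C(=C)CC[C@@H]2[C@]1(C)CCC[C@]2(C)C=O`: > 40000 nM

For the measured compounds named here, compound 1 is the only member of the set with a numerical value in this assay. For compound 2 the read-out is a limit of the assay, not a number: > 40000 nM. For compound 3 likewise only a limit is reported, > 40000 nM. So compound 2 stands with compound 3 at the limit of > 40000 nM in this assay, at which 2 of the 3 values shown sit, and the actual potency of either cannot be placed relative to the other from these figures.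

Compound 4, `C=C[C@]1(C)O[C@H]1C[C@H]1C(=C)CC[C@@H]2[C@]1(C)CCC[C@]2(C)C(=O)O`, has not yet been measured in this assay. It differs from compound 2 in one place: a group of 6 heavy atoms (5 carbon, 1 oxygen; one three-membered non-aromatic ring with 1 hetero atom) in place of a group of 5 heavy atoms (4 carbon, 1 oxygen; no ring), on a saturated chain carbon bound to a saturated ring carbon. Going by the values given here, no step between two measured compounds is available to gauge what this exchange does, since compound 1 and compound 3 differ from compound 2 in several places at once. With compound 2 sitting at the limit, the expectation for the step from compound 2 to compound 4 is a change of about a number no higher from compound 2 to compound 4 (the limit leaves the size open), that is, nothing beyond the scatter, with a real chance that only a limit is returned again. The estimate for compound 4 in this assay is 40000 nM, ranging from 15000 nM to 100000 nM.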

Compound 4, half-maximal inhibitory concentration: > 40000 nM
Compound 4: a limit, no number; the forecaster's own chance of this, stated with the estimate: 70%; the middle value sits exactly at the limit.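

Compound 4, like compound 2, returns only a limit of the assay and no number, so no step between the two can be read: the limit of > 40000 nM in this assay, at which 3 of the 4 values shown sit.

The compounds shown leave open what the exchange of the 2-formylprop-1-en-1-yl group for the three-membered ring group does to potency, and how compound 2, compound 3 and compound 4 rank against one another.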